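A Weak Inhibitor Loses Two Halogens

The source may report more compounds than this note shows. Statements on the series, on what has been measured and on what is new or still open speak of the compounds shown alone.

Compound 1 `NC(=O)c1cc(-c2ccc(-c3ccc(Cl)cc3Cl)cc2)n(-c2ccccn2)n1`: > 100000 nM in an assay on isolated protein for inhibition of methionine--tRNA ligase, cytoplasmic (Homo sapiens); a lower number here means a stronger inhibitor, a higher number a weaker inhibitor; this is a limit of the assay, not a number.
Compound 2 `O=C(O)c1cc(-c2ccc(-c3ccc(Cl)cc3Cl)cc2)n(Cc2cccnc2)n1`: > 100000 nM in this assay; again a limit of the assay, not a number.
Compound 3 `O=C(O)c1cc(-c2ccc(-c3ccc(F)c(Cl)c3)cc2)n(-c2ccc(Cl)cc2Cl)n1`: 20900 nM in this assay.

Three compounds share a core, and only one of them has given a number. Going by the values given here, compound 3 is that one; its value is weak, yet it is the only measured number, since the other two values sit at the limit of > 100000 nM in this assay, at which 2 of the 3 values shown sit. There is no measured step between any two of these compounds, so compound 3 stands alone as the single point of reference.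

Compound 4 `O=C(O)c1cc(-c2ccc(-c3ccccc3)cc2)n(-c2ccc(Cl)cc2Cl)n1` has not yet been measured. Its change from compound 3 is phenyl in place of 3-chloro-4-fluorophenyl on an aromatic carbon. Two halogen atoms on the outer ring are removed, leaving a bare phenyl.

With compound 3 already weak, the expected step from compound 3 to compound 4 in this assay is a 2.4-fold higher number from compound 3 to compound 4 (0.38 log units; beyond the scatter), toward a weaker inhibitor, and it may well not pass beyond the scatter. The estimate for compound 4 is 50000 nM, within a range from 15000 nM to 150000 nM, with a fair chance that only a limit is reported.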

Compound 4, half-maximal inhibitory concentration: 44300 nM
Compound 4: the middle estimate sits 1.1-fold (0.05 log units) above what was measured, within the range that was stated.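

In this assay, going by these compounds alone, removing the chlorine and the fluorine together gives a 2.1-fold higher number from compound 3 to compound 4 (0.33 log units; beyond the scatter), the first measured step in this set. So the two halogens on the outer ring make a modest difference, and compound 4 with its bare phenyl still gives a number, 44300 nM. The step can be read only because both compounds gave numbers, which is not true of every compound here: the limit of > 100000 nM in this assay, at which 2 of the 4 values shown sit.

On these data alone, the two halogens left in a single step, so it remains open whether the change belongs to the chlorine, to the fluorine or to both. As far as these compounds go, it is also open how a methoxy group or a nitrile on the outer ring, in place of these halogens, would read in this assay.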